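The source may report more compounds than this note shows. Statements on the series, on what has been measured and on what is new or still open speak of the compounds shown alone.

Of the compounds shown here, two that share one core have already been measured in a physicochemical assay for lipophilicity, measured as octanol-water partition; on this read-out lower numbers stand for lower lipophilicity and higher numbers for higher lipophilicity. Compound 1 `CC1=C(C(=O)OCc2ccccn2)C(c2ccc(Br)cc2)C2=C(CCCC2=O)N1` gives 2.42 in this assay. Compound 2 `COc1cc(C2C(C(=O)OCc3ccccn3)=C(C)NC3=C2C(=O)CCC3)cc(OC)c1OC` gives 2.17 in this assay. These two numbers sit within the scatter of repeated measurements of each other, so on this read-out compound 1 cannot be told apart from compound 2; it is simply one of two close values.

The compound still to be measured is compound 3 `CC1=C(C(=O)OCc2ccccn2)C(c2cccc([N+](=O)[O-])c2)C2=C(CCCC2=O)N1`. It differs from compound 1 in a single place: 3-nitrophenyl in place of 4-bromophenyl on a saturated ring carbon. A 4-bromophenyl on a saturated ring carbon thus gives way to a 3-nitrophenyl at the same place. Within the data shown here, no measured pair in this set differs in exactly this way, so the size of the step cannot be read off a measured example and has to be estimated.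

The step expected in this assay is a number 1.02 log units lower from compound 1 to compound 3 (beyond the scatter), a fall well beyond the scatter. Compound 3 is therefore estimated at 1.4 in this assay, with a range from 1 to 1.9.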

Compound 3, partition coefficient: 1.88
Compound 3: middle estimate off by 0.48 log units, on the low side, and the stated range covers the measured number.
By their numbers in this assay, from the lowest: compounds 3, 2 and 1 (each within the scatter of the next, the first and the last beyond it).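

Among these compounds, putting 3-nitrophenyl in place of 4-bromophenyl on the saturated ring carbon gives a number 0.54 log units lower from compound 1 to compound 3 (beyond the scatter) in this assay and is the first single-place change in this set whose step can be read from two measured compounds. It shows that changing only the group at this carbon, with the rest of the core of compound 1 held constant, can move the read-out further than repeated measurements would scatter. The step is modest in size, so this one change is clearly visible without being large. Nothing measured here accounts for the size of this step.

The swap alters two things at once, the kind of substituent on the aromatic ring and where that substituent sits, so the shared step cannot be divided between them. A 4-nitrophenyl or a 3-bromophenyl at the same carbon would separate the two, while a plain phenyl or an aminophenyl there would show how far the read-out can travel at this place.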